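A 2-hydroxyethyl group added to compound 2

The compounds below may be only part of what the source reports. "The series", "measured", "known", "first", "only" and "open" are said of these compounds alone.

Among the measured compounds shown here, in an ADME assay on microsomes (Homo sapiens) for metabolic stability (on this read-out higher numbers stand for fast clearance and lower numbers for slow clearance), compound 2 (`Cc1cc(C(F)(F)F)c2cccc(OCc3c(Cl)ccc(S(=O)(=O)N4CCCCC4)c3Cl)c2n1`) gives 233 mL/min/kg as the higher of the two numbers so far, against compound 1 (`Cc1cc(C(F)(F)F)c2cccc(OCc3c(Cl)ccc(S(=O)(=O)N4CCC[C@H]4C(=O)O)c3Cl)c2n1`) at 8.33 mL/min/kg in the same read-out. Compound 3 (`Cc1cc(C(F)(F)F)c2cccc(OCc3c(Cl)ccc(S(=O)(=O)N4CCC(CCO)CC4)c3Cl)c2n1`) carries 2-hydroxyethyl in place of hydrogen on a saturated ring carbon, three ring bonds from the ring nitrogen. For the measured compounds named here, the one measured step at this sulfonyl sulfur (a 28-fold higher number from compound 1 to compound 2 (1.45 log units; beyond the scatter)) was large but exchanged a different group, so it shows only that changes here can move this assay strongly. A much smaller fall is expected (a 1.9-fold lower number from compound 2 to compound 3 (0.29 log units; within the scatter)). Compound 3 is estimated at 120 mL/min/kg (range 45 mL/min/kg to 280 mL/min/kg).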

Compound 3, clearance: 367 mL/min/kg
For compound 3 the middle estimate is 3.1-fold (0.49 log units) below the measured one, and the stated range ends below it.
By their numbers in this assay, from the lowest: compound 1; then compounds 2 and 3 (each within the scatter of the next).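

In this assay, 2-hydroxyethyl in place of hydrogen on a saturated ring carbon, three ring bonds from the ring nitrogen, gives a step within the scatter (a 1.6-fold higher number from compound 2 to compound 3 (0.20 log units; within the scatter)), so this addition does not separate compound 3 from compound 2. The 2-carboxypyrrolidin-1-yl group of compound 1 still stands well apart from this new 4-(2-hydroxyethyl)piperidin-1-yl group (a 44-fold higher number from compound 1 to compound 3 (1.64 log units; beyond the scatter)). No measurement at hand accounts for this result. Going by these compounds, whether a carboxylic acid, an amine or a longer chain on the same saturated ring carbon would move this read-out remains open.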